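Swapping the methoxybenzyl arm for phenethyl

This account rests on a few compounds, and the source may have more. Where it says the series, first, only, none or still open, it means among the compounds named here.

Compound 1 `C=C(Br)C(=O)Nc1cccc(-c2cn3nc(Cc4cccc(OC)c4)sc3n2)c1` gives 1100 nM in a functional assay on FM3A cells (Mus musculus) for inhibition, read by cell counting, with a stated time of 2 days; a higher number here means a weaker inhibitor, a lower number a stronger inhibitor.
Compound 2 `COc1cccc(Cc2nn3cc(-c4cccc(N)c4)nc3s2)c1` gives 10000 nM in this assay.

Of the two numbers measured, compound 1 stands lowest; its nearest neighbour is compound 2, reached by a 9.1-fold higher number from compound 1 to compound 2 (0.96 log units; beyond the scatter), a change of hydrogen in place of (1-bromoethenyl)carbonyl on a nitrogen on an aromatic ring.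

Compound 3 `C=C(Br)C(=O)Nc1cccc(-c2cn3nc(CCc4ccccc4)sc3n2)c1` is not yet measured. It differs from compound 1 in one place: benzyl in place of 3-methoxyphenyl on a saturated chain carbon bound to an aromatic carbon. Among the compounds with values here, compound 3 keeps the (1-bromoethenyl)carbonyl on the nitrogen on the aromatic ring that compound 1 carries, so the one measured step, from compound 1 to compound 2, does not bear on this change. Within the data shown here, no measured step addresses the exchange of 3-methoxyphenyl for benzyl on the saturated chain carbon bound to an aromatic carbon. With nothing to point in either direction, the expectation for compound 3 in this assay is a step of a 1.4-fold higher number from compound 1 to compound 3 (0.13 log units; within the scatter), which is not beyond the scatter. Compound 3 is therefore estimated at 1500 nM, with a range from 400 nM to 6000 nM.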

Compound 3, half-maximal inhibitory concentration: 2600 nM
Compound 3: the middle estimate sits 1.7-fold (0.24 log units) below what was measured; the measured number falls inside the stated range.
By their numbers in this assay, from the lowest: compound 1; then compound 3; then compound 2.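

Within the data shown here, the arm on the saturated chain carbon bound to an aromatic carbon had not been varied in the earlier compounds, and in this assay the change from 3-methoxybenzyl to phenethyl gives a 2.4-fold higher number from compound 1 to compound 3 (0.37 log units; beyond the scatter). This shows that the position is sensitive to the change, though the step is modest and compound 3 keeps a measurable value with the (1-bromoethenyl)carbonyl still in place. Among these compounds, the single exchange both removes the methoxy group and alters the chain that links the phenyl ring to the core, and nothing available gives a reason for the step.

The compounds shown leave open which of these two differences carries the step, and a plain benzyl arm or a 3-methoxyphenethyl arm would each alter only one of them. Also open, going by these compounds, is how this position responds to a longer chain such as 3-phenylpropyl, or to an arm ending in an amine or a carboxylic acid in place of the phenyl ring.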